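Swapping the sulfonyl aryl group in a quinoline series

This account rests on a few compounds, and the source may have more. Where it says the series, first, only, none or still open, it means among the compounds named here.

Measured compounds:
- compound 1, `Cc1ccc(S(=O)(=O)c2cnc3ccc(F)cc3c2N2CCC(C)CC2)cc1F`, 86%
- compound 2, `Cc1ccc(S(=O)(=O)c2cnc3ccc(Cl)cc3c2N2CCC(C)CC2)cc1F`, 68%

Both compounds were tested in an assay on isolated protein for displacement of a labelled ligand from metabotropic glutamate receptor 5 (Homo sapiens), with a stated time of 60 min, tested at 1 uM; a lower number here means less inhibition, a higher number more inhibition at the concentration tested (going by the name of the read-out). Compound 1 gives 86%, and compound 2 gives 68%. Within the data shown here, the only measured step is a number 18 percentage points lower from compound 1 to compound 2 (beyond the scatter), so compound 2 stands at the lower of the two numbers, with compound 1 sitting higher by an amount beyond the scatter.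

The next compound, compound 3, `CC1CCN(c2c(S(=O)(=O)c3cc(F)cc(F)c3)cnc3ccc(Cl)cc23)CC1`, keeps the chloro-bearing core of compound 2 and alters the group on the sulfonyl sulfur: 3,5-difluorophenyl in place of 3-fluoro-4-methylphenyl on a sulfonyl sulfur. Among the measured compounds shown here, no measured step touches this part of the molecule; the one known step concerns a different position, so it gives no direct guide to the size or direction of the change in this assay. For the measured compounds named here, with only two measured compounds, the expectation is that compound 3 stays in the same broad region as compound 2, with a wide range to reflect the lack of evidence. Compound 3 is therefore estimated at 60%, between 35% and 82%, which would mean an expected step of a number 8 percentage points lower from compound 2 to compound 3 (within the scatter).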

Compound 3, a percentage reported as inhibition, at one concentration (the size of the read-out at that concentration, not a potency): 93%
The estimate for compound 3 lay 33 percentage points below the measured number; measured number above the stated range.
By their numbers in this assay, from the lowest: compound 2; then compounds 1 and 3 (each within the scatter of the next).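

In this assay, putting 3,5-difluorophenyl in place of 3-fluoro-4-methylphenyl on a sulfonyl sulfur gives a number 25 percentage points higher from compound 2 to compound 3 (beyond the scatter), which shows that the group at this position can change the read-out and that this particular change raises it. The two groups are closely matched: they have the same heavy-atom count and the same single aromatic ring of carbon only, with neither carrying hydrogen-bond donors or acceptors, so the step comes from an exchange that differs only in its carbon and fluorine content. Nothing available here bears on the reason for this step.

The compounds shown leave open whether the same exchange would give a similar step on the fluoro-bearing core of compound 1, and whether the size of the step depends on the chloro group at all. They also leave open how the read-out would respond to groups of a different kind on the sulfonyl sulfur, such as unsubstituted phenyl, a pyridine ring or a saturated cyclohexyl ring.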